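The source may hold more compounds than are shown below. What is called first, only, known or untested is meant among the compounds shown, and "the series" means these compounds.

Compound 1 `CCc1ccc(-c2nc3ccccn3c2Sc2ccccc2)cc1`: 52100 nM
Compound 2 `COc1ccc(-c2nc3ccccn3c2Sc2ccccc2)cc1`: > 100000 nM (a limit of the assay)

In a functional assay on HeLa cells (Homo sapiens) for inhibition, read by MTT assay, with a stated time of 48 h (a lower number here means a stronger inhibitor, a higher number a weaker inhibitor), compound 1 gives 52100 nM, a weak result. Compound 2 has no exact value, only a limit: > 100000 nM. Within the data shown here, the one measured step, methoxy in place of ethyl on an aromatic carbon, is an at least 1.9-fold higher number from compound 1 to compound 2 (0.28 log units; that floor lies within the scatter). It therefore shows no firm change, and it bears only loosely on what comes next.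

Compound 3 `C(=C/c1nc2ccccn2c1Sc1ccccc1)\c1ccccc1` keeps the shared core and the phenylsulfanyl group but carries 2-phenylethenyl in place of 4-methoxyphenyl on an aromatic carbon. Among the measured compounds shown here, this swaps a whole group, and no measured step covers such a swap. Like compound 1, compound 3 carries no methoxy, so the nearest guide is the value of compound 1, 52100 nM. A modest move to a lower number in this assay is therefore expected, with inhibition staying weak. The estimate corresponds to an at least 2.2-fold lower number from compound 2 to compound 3 (0.34 log units; beyond the scatter), and this expected step is uncertain. For compound 3 the expected value is 45000 nM, with an estimated range from 12000 nM to 100000 nM.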

Compound 3, half-maximal inhibitory concentration: 35500 nM
Compound 3: the middle estimate sits 1.3-fold (0.10 log units) above what was measured; measured number inside the range.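

In this assay, among these compounds, 2-phenylethenyl in place of 4-methoxyphenyl on an aromatic carbon of the five-membered aromatic ring gives an at least 2.8-fold lower number from compound 2 to compound 3 (0.44 log units; beyond the scatter), the first step in this short series that clears the usual scatter, so what sits at this position can shift the result. That step gives only a minimum size, as compound 2 has no exact value, only a limit of the assay: the limit of > 100000 nM in this assay, at which 1 of the 3 values shown sits. The change from the ethyl-bearing analogue gives a 1.5-fold lower number from compound 1 to compound 3 (0.17 log units; within the scatter), so 2-phenylethenyl and 4-ethylphenyl cannot be told apart here, and compound 3, at 35500 nM, remains a weak inhibitor.

The compounds shown leave open whether the double bond of 2-phenylethenyl matters at all, or whether a different kind of group at this position, such as an amine, a carboxylic acid or a longer chain, could give a much lower number. They also leave open how far the phenylsulfanyl group contributes, as it stays the same in all three compounds.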